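This account rests on a few compounds, and the source may have more. Where it says the series, first, only, none or still open, it means among the compounds named here.

The three measured compounds share one core and differ only in the outer aryl group. Compound 1 `N=C(N)c1ccc(-c2ccc(-c3cc(Cl)cc(Cl)c3)s2)s1` gives 2330 nM in a functional assay on RPMI-8226 cells (Homo sapiens) for inhibition, read by sulforhodamine B assay, with a stated time of 48 h; a lower number here means a stronger inhibitor of growth, a higher number a weaker inhibitor of growth. Compound 3 `N=C(N)c1ccc(-c2ccc(-c3ccc4ccccc4c3)s2)s1` gives 2300 nM in this assay. Compound 2 `N=C(N)c1ccc(-c2ccc(-c3ccc(Cl)cc3)o2)o1` gives 2120 nM in this assay. Among the compounds with values here, the number for compound 2 is the lowest of the three, yet it lies within the usual scatter of both compound 1 and compound 3, so the three cannot be told apart on these data; no single-point step between measured compounds is available.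

Compound 4 `N=C(N)c1ccc(-c2ccc(-c3ccc(F)cc3)o2)o1` is the unmeasured partner of compound 2. The change is fluoro in place of chloro on an aromatic carbon. Within the data shown here, nothing among the measured compounds tests this particular exchange, so the expectation rests on the narrow spread of the measured values alone. The step from compound 2 to compound 4 is expected to be a 1.3-fold higher number from compound 2 to compound 4 (0.12 log units; within the scatter), that is, small and not clearly beyond the scatter, if anything toward a slightly higher number. Compound 4 is accordingly estimated at 2800 nM in this assay, with a range from 1400 nM to 5600 nM.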

Compound 4, concentration for 50% growth inhibition: 2480 nM
The estimate for compound 4 lay 1.1-fold (0.05 log units) above the measured number; the range from low to high includes it.
By their numbers in this assay, from the lowest: compounds 2, 3, 1 and 4 (each within the scatter of the next).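

In this assay the exchange of fluoro for chloro on an aromatic carbon, para to a large group, gives a 1.2-fold higher number from compound 2 to compound 4 (0.07 log units; within the scatter) and so stays within the scatter. Within the data shown here, this is the first comparison here between two compounds that differ in one place, and it shows that these two halogens cannot be told apart at this position in this assay. No supporting measurement is available to explain this result.

The compounds shown leave open whether a group other than a halogen at this position, such as an amine, a carboxylic acid or a longer chain, would move the number beyond the scatter. They also leave open whether the same exchange would behave alike on the core of compound 1.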